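Acetylation of the aryl amine in the weaker stereoisomer

A few compounds are considered here, and "the series" means these few. Any claim that something is new, unique, unknown or untested is made for them only; others in the source may bear on it.

Two stereoisomers share one core. Compound 1 `CN1CCC[C@H]1[C@@H]1COc2ccc(N)cc2O1` and compound 2 `CN1CCC[C@H]1[C@H]1COc2ccc(N)cc2O1` have the same atoms and bonds and differ only in the configuration drawn at one saturated ring carbon. In an assay on membranes from Cerebral cortex for displacement of a labelled ligand from Neuronal acetylcholine receptor; alpha4/beta2 (Rattus norvegicus), with a stated time of 5 min (a higher number here means a weaker inhibitor, a lower number a stronger inhibitor), compound 1 gives 22 nM, and in this assay compound 2 gives 140 nM. For the measured compounds named here, the step of a 6.4-fold higher number from compound 1 to compound 2 (0.80 log units; beyond the scatter) is therefore the only measured step, and the inversion at that ring carbon is the sole structural change behind it (the fact that compounds 1 and 2 differ only in the configuration as drawn). Compound 2 stands with the higher number of the two, the weaker inhibitor.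

Compound 3 `CC(=O)Nc1ccc2c(c1)O[C@@H]([C@@H]1CCCN1C)CO2` keeps the configuration of compound 2 and changes elsewhere: acetyl in place of hydrogen on a nitrogen on an aromatic ring. Going by the values given here, no measured step touches this nitrogen; the step between compound 1 and compound 2 concerns a stereocentre only and offers no guide to what an acetyl on the aromatic amine does. The expectation must therefore rest on compound 2 alone, with a wide range. Compound 3 is estimated at 280 nM, between 50 nM and 1600 nM, which means an expected step of a 2.0-fold higher number from compound 2 to compound 3 (0.30 log units; within the scatter), not firmly beyond the scatter in either direction.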

Compound 3, inhibition constant: 46000 nM
Estimate against measurement, compound 3: 160-fold (2.22 log units) below; measured number above the stated range.
By their numbers in this assay, from the lowest: compound 1; then compound 2; then compound 3.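

Amino to acetamido on this nitrogen on an aromatic ring is the first change among these compounds that touches the aromatic amine, and in this assay it gives a 330-fold higher number from compound 2 to compound 3 (2.52 log units; beyond the scatter). For the compounds shown here, this step is much larger than the one from the change of configuration, a 6.4-fold higher number from compound 1 to compound 2 (0.80 log units; beyond the scatter), so in this pair the hydrogen on that nitrogen matters far more to the number than the drawn configuration at the ring carbon does in the other pair. The only available evidence concerns the configuration of compounds 1 and 2, and nothing shown explains why acetyl in place of hydrogen has so large an effect.

The compounds shown leave open whether the large step belongs to acetyl specifically or would also come with a methyl group, a formyl group or a longer acyl chain such as propanoyl on the same nitrogen. They also leave open whether acetyl on the aromatic amine of compound 1, with its stronger starting value and other configuration, would bring a step of similar size.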